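A few compounds are considered here, and "the series" means these few. Any claim that something is new, unique, unknown or untested is made for them only; others in the source may bear on it.

Measured compounds:
compound 1 `O=Cc1ccc(-c2cn3ccnc3c(-c3ccc4ncn(C5CCCCC5)c4c3)n2)cc1` — 20.9%
compound 2 `Brc1ccc(-c2cn3ccnc3c(-c3ccc4ncn(C5CCCCC5)c4c3)n2)cc1` — 16.2%

In a functional assay on EKVX cells (Homo sapiens) for inhibition, read by sulforhodamine B assay, with a stated time of 48 h, tested at 10 uM (on this read-out higher numbers stand for more inhibition at the one concentration tested (going by the name of the read-out) and lower numbers for less inhibition), compound 1 gives 20.9%, the highest of the two numbers seen here, while compound 2 gives 16.2%. Within the data shown here, the only step between measured compounds, a number 4.7 percentage points lower from compound 1 to compound 2 (within the scatter), exchanges one group on the aromatic carbon and changes the number by less than the usual scatter, so these two compounds cannot be told apart on this assay.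

Compound 3 `O=Cc1ccc(-c2cn3ccnc3c(-c3ccc4ncn(Cc5ccccc5)c4c3)n2)cc1` is not yet measured. It differs from compound 1 at another place: benzyl in place of cyclohexyl on an aromatic nitrogen. Among the measured compounds shown here, no measured step touches that aromatic nitrogen, so nothing in the data speaks to how large a change at this position might be. For the measured compounds named here, the only step available, a number 4.7 percentage points lower from compound 1 to compound 2 (within the scatter), shows that a change elsewhere in the molecule left the number within scatter, which is the sole guide here.

Compound 3 is therefore expected to sit close to compound 1, with an estimated step of a number 0.9 percentage points lower from compound 1 to compound 3 (within the scatter). The estimate for compound 3 in this assay is 20%, with a range from 5% to 40%.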

Compound 3, a percentage reported as inhibition, at one concentration (the size of the read-out at that concentration, not a potency): 20.9%
Compound 3: middle estimate off by 0.9 percentage points, on the low side, and the stated range covers the measured number.
By their numbers in this assay, from the lowest: compounds 2, 1 and 3 (each within the scatter of the next).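

In this assay, among these compounds, benzyl in place of cyclohexyl on an aromatic nitrogen gives no change at the digits printed from compound 1 to compound 3 (within the scatter), and this is the first reading at this position, since the earlier step touched only the aromatic carbon that carries formyl or bromo. It shows that this nitrogen of the five-membered aromatic ring can carry either a six-membered non-aromatic ring of carbon only or a benzyl group, with its six-membered aromatic ring of carbon only, without the two compounds being told apart on this read-out, where compound 3 gives 20.9%. Nothing on hand offers an explanation for why the two groups read alike.

Going by these compounds, both groups compared on this nitrogen are made of carbon only and hold one six-membered ring, so it remains open whether a morpholine on a short chain, a carboxylic acid on a longer chain or a plain methyl would read any differently. On these data alone, it also remains open whether benzyl on this nitrogen would read the same with bromo in place of formyl on the aromatic carbon.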